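The compounds below may be only part of what the source reports. "The series", "measured", "known", "first", "only" and "open" are said of these compounds alone.

Measured in a functional assay on a cell-free system (Platelet, plasma, Homo sapiens) for inhibition, read by turbidimetry, with a stated time of 3 min; on this read-out higher numbers stand for weaker inhibition and lower numbers for stronger inhibition:
- compound 1 `COc1ccc(-n2nc(C(=O)N3CCN(c4ccc(C(F)(F)F)cn4)CC3)cc2-c2ccc(Cl)cc2)nn1`: 5490 nM
- compound 2 `CS(=O)(=O)c1ccc(-n2nc(C(=O)N3CCCCC3)cc2-c2ccc(Cl)cc2)nn1`: 19600 nM
- compound 3 `CS(=O)(=O)c1ccc(-n2nc(C(=O)N3CCOCC3)cc2-c2ccc(Cl)cc2)nn1`: > 20000 nM, a limit and not a number

Compound 3 has no number on this read-out, only (the limit of > 20000 nM in this assay, at which 1 of the 3 values shown sits). Compound 4 `O=C(c1cc(-c2ccc(Cl)cc2)n(-c2ccc(=O)[nH]n2)n1)N1CCOCC1` keeps the core of compound 3 and replaces the 6-(methylsulfonyl)pyridazin-3-yl group on an aromatic nitrogen: a group of 7 heavy atoms (4 carbon, 2 nitrogen, 1 oxygen; one six-membered aromatic ring with 2 hetero atoms) in place of a group of 10 heavy atoms (5 carbon, 2 nitrogen, 2 oxygen, 1 sulfur; one six-membered aromatic ring with 2 hetero atoms), on an aromatic nitrogen. Among the measured compounds shown here, no measured step touches that place. The only one, an at least 1.0-fold higher number from compound 2 to compound 3 (0.00 log units; that floor lies within the scatter), concerns the group on the carbonyl carbon and gives no size for this change. No step beyond the scatter is therefore expected in this assay. The estimated step is a step that the limit leaves unreadable from compound 3 to compound 4. For compound 4 the expected value is 25000 nM, with an estimated range from 10000 nM to 60000 nM.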

Compound 4, half-maximal inhibitory concentration: 12600 nM
Estimate against measurement, compound 4: 2.0-fold (0.30 log units) above; measured number inside the range.
By their numbers in this assay, from the lowest: compound 1; then compounds 4 and 2 (each within the scatter of the next). At a limit, above all of these: compound 3.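

In this assay, among the compounds shown here, the earlier compounds gave no step at the aromatic nitrogen, and this change now gives a first one, though only as a floor within the scatter (an at least 1.5-fold lower number from compound 3 to compound 4 (0.20 log units; that floor lies within the scatter)). With the morpholin-4-yl amide kept, the 6-(methylsulfonyl)pyridazin-3-yl group is thus not required for compound 4 to read as a number. From the compounds shown here alone, compound 3 has a limit, not a number, so the true size of the step stays unknown: the limit of > 20000 nM in this assay, at which 1 of the 4 values shown sits.

Going by these compounds, whether an amine or a carboxylic acid in place of the methylsulfonyl group would change the read-out stays open. So does the effect of this change on the piperidin-1-yl amide.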